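The compounds below may be only part of what the source reports. "The series", "measured", "known", "first", "only" and "open" are said of these compounds alone.

Going by the values given here, compound 1 `CC1=CC[C@H](C(C)C)c2cc(C)c(OC(=O)Nc3ccccc3)cc21` stands highest of the two numbers so far: in a functional assay on U-251 cells (Homo sapiens) for antiproliferative activity, read by sulforhodamine B assay, with a stated time of 48 h, tested at 50 uM (a higher number here means more inhibition at the concentration tested (going by the name of the read-out), a lower number less inhibition), compound 1 gives 100%. Compound 2 `Cc1cc2c(C(C)C)ccc(C)c2cc1OC(=O)c1ccc(C(F)(F)F)cc1` differs from compound 1 in several places at once. In this assay compound 2 gives 16.5%, a number far below that of compound 1 and beyond the scatter. Compound 3 `COc1ccc(C(=O)Oc2cc3c(cc2C)[C@@H](C(C)C)CC=C3C)cc1` is compound 1 with 4-methoxyphenyl in place of anilino on a carbonyl carbon. Among the compounds with values here, compound 2 is the only other compound in which the carbonyl carbon carries a ring in place of the anilino group, and for compound 2 the value 16.5% weighs on the expectation. The step of a number 55 percentage points lower from compound 1 to compound 3 (beyond the scatter) is expected to be a drop beyond the scatter. Compound 3 is therefore estimated at 45% in this assay, within 10% to 85%.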

Compound 3, a percentage reported as inhibition, at one concentration (the size of the read-out at that concentration, not a potency): 37%
Compound 3: the middle estimate sits 8 percentage points above what was measured, within the range that was stated.
By their numbers in this assay, from the lowest: compound 2; then compound 3; then compound 1.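

In this assay, going by these compounds alone, the carbonyl carbon gives the first single-place comparison: the step is a number 63 percentage points lower from compound 1 to compound 3 (beyond the scatter), with 4-methoxyphenyl in place of anilino. At this position, the anilino group therefore cannot be exchanged for 4-methoxyphenyl without a large loss. The change removes a nitrogen and a hydrogen-bond donor and adds an oxygen and a hydrogen-bond acceptor, and this one step cannot separate these differences. No measurement here bears on the cause of the step. Still open, going by these compounds, is whether benzylamino or plain phenyl on the carbonyl carbon would stay closer to compound 1 or to compound 3.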